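A few compounds are considered here, and "the series" means these few. Any claim that something is new, unique, unknown or untested is made for them only; others in the source may bear on it.

In a functional assay on HCT-116 cells (Homo sapiens) for antiproliferative activity, read by MTT assay, with a stated time of 72 h (a lower number here means a stronger inhibitor, a higher number a weaker inhibitor), compound 1 `COc1cc(CCc2ccccc2)cc(OC)c1O` gives 530 nM, compound 2 `COc1cc(CCc2ccc(Br)cc2)cc(OC)c1O` gives 15900 nM and compound 3 `COc1cc(CCc2ccc(Cl)cc2)cc(OC)c1O` gives 330 nM. Compound 3 therefore stands level with compound 1 and far from compound 2. Chloro in place of hydrogen gave a 1.6-fold lower number from compound 1 to compound 3 (0.21 log units; within the scatter), which is within the scatter. Bromo in place of hydrogen gave a 30-fold higher number from compound 1 to compound 2 (1.48 log units; beyond the scatter), and chloro in place of bromo gave a 48-fold lower number from compound 2 to compound 3 (1.68 log units; beyond the scatter), both large steps.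

Compound 4 `COc1cc(CCc2ccc([N+](=O)[O-])cc2)cc(OC)c1O` has not yet been measured. It carries nitro in place of chloro on an aromatic carbon, para to a large group (nitro in place of chloro on an aromatic carbon). Going by the values given here, no measured compound carries nitro, so the steps above bear on it only indirectly, and they disagree in size. Compound 2, at 15900 nM, shows that a change at this place can bring a large rise, so a moderate upward step is expected in this assay. The estimate is a 3.0-fold higher number from compound 3 to compound 4 (0.48 log units; beyond the scatter). Compound 4 is expected at 1000 nM, with an estimated range of 250 nM to 6000 nM.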

Compound 4, half-maximal inhibitory concentration: 3160 nM
Compound 4: middle estimate off by 3.2-fold (0.50 log units), on the low side; the range from low to high includes it.
By their numbers in this assay, from the lowest: compounds 3 and 1 (each within the scatter of the next); then compound 4; then compound 2.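

In this assay, going by these compounds alone, nitro in place of hydrogen gives a 6.0-fold higher number from compound 1 to compound 4 (0.78 log units; beyond the scatter) and so shows that bromo is not the only group at this position that raises the number. Nitro does not go as far as bromo, as nitro in place of bromo gives a 5.0-fold lower number from compound 2 to compound 4 (0.70 log units; beyond the scatter), so a rise at this position can differ in size from one group to the next. Nitro in place of chloro gives a 9.6-fold higher number from compound 3 to compound 4 (0.98 log units; beyond the scatter) and leaves chloro as the only one of the three replacements of hydrogen whose step stays within the scatter.

No measurement here explains why the groups fall in this order. From the compounds shown here alone, it also remains open whether an amine or a carboxylic acid at this position would stay level with chloro or raise the number as nitro and bromo do.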